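Working notes: aryl swap on the shared core, cytotoxicity

The compounds below may be only part of what the source reports. "The series", "measured", "known", "first", "only" and "open" are said of these compounds alone.

Measured compounds:
compound 1, `COc1ccc(-c2cc(C(C)=O)c3[nH]c(-c4ccccc4)cc3c2)cc1`: 99.2%
compound 2, `COc1ccc(-c2cc(C(C)=O)c3[nH]c(-c4ccc(F)cc4)cc3c2)cc1`: 88.4%
compound 3, `COc1ccc(-c2cc(C(C)=O)c3[nH]c(-c4ccc(OC)cc4)cc3c2)cc1`: 96.5%

In a functional assay on MCF7 cells (Homo sapiens) for cytotoxicity, read by MTT assay, with a stated time of 2 days, tested at 0.1 uM (a lower number here means a stronger effect, a higher number a weaker effect of the compound at the concentration tested), compound 1 gives 99.2%, the highest of the three numbers. The nearest number is a number 2.7 percentage points lower from compound 1 to compound 3 (within the scatter); the furthest is a number 10.8 percentage points lower from compound 1 to compound 2 (beyond the scatter). Between the other two, a number 8.1 percentage points higher from compound 2 to compound 3 (within the scatter). Within the data shown here, only the step to compound 2 is beyond the scatter, and it is modest.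

Compound 4, `CC(=O)c1cc(/C=C/c2ccc(F)cc2)cc2cc(-c3ccccc3)[nH]c12`, is not yet measured. Relative to compound 1 the change is 2-(4-fluorophenyl)ethenyl in place of 4-methoxyphenyl on an aromatic carbon. Among the measured compounds shown here, all three measured steps alter the phenyl group on the other side of the shared core and leave the changed place untouched, so none of them bears directly on this step; the only exchange involving fluoro, a number 10.8 percentage points lower from compound 1 to compound 2 (beyond the scatter), is modest and at a different place. For the measured compounds named here, with no direct precedent, a step of no more than the scatter is expected, estimated as a number 6.2 percentage points lower from compound 1 to compound 4 (within the scatter). Compound 4 is therefore expected to give about 93%, in a range from 78% to 103%.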

Compound 4, a percentage reported as activity, at one concentration (the size of the read-out at that concentration, not a potency): 89.7%
Beside the measured number, compound 4's estimate is 3.3 percentage points above it, within the range that was stated.
By their numbers in this assay, from the lowest: compounds 2, 4, 3 and 1 (each within the scatter of the next, the first and the last beyond it).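

Among these compounds, this is the first measured change at the place that carries the 4-methoxyphenyl group in compound 1, as all earlier steps altered the phenyl group on the other side of the shared core. In this assay, 2-(4-fluorophenyl)ethenyl in place of 4-methoxyphenyl gives a number 9.5 percentage points lower from compound 1 to compound 4 (within the scatter), so a change that adds a double bond outside aromatic rings and removes the hydrogen-bond acceptor of the leaving group stays within the scatter at this single concentration. The terminal fluoro and the ethenyl link enter together, so their contributions cannot be separated, and no measurement available here accounts for the result.

The compounds shown leave open whether a plain 4-fluorophenyl group at this place would read like compound 4. Also open, as far as these compounds go, is whether an amine or a carboxylic acid there would give a step beyond the scatter.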